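Replacing Phenoxy with 4-Methyl-4H-1,2,4-triazol-3-yl

The compounds below may be only part of what the source reports. "The series", "measured", "known", "first", "only" and "open" are said of these compounds alone.

Compound 1, `O=C(Nc1cccc(Oc2ccccn2)c1)C1CCCN(C(=O)c2cc(C(F)(F)F)cc(C(F)(F)F)c2)C1`: 0%
Compound 2, `CCc1cccc(NC(=O)C2CCCN(C(=O)c3cc(C(F)(F)F)cc(C(F)(F)F)c3)C2)c1`: 0%
Compound 3, `O=C(Nc1cccc(Oc2ccccc2)c1)C1CCCN(C(=O)c2cc(C(F)(F)F)cc(C(F)(F)F)c2)C1`: 1%

Of the compounds shown here, three on a shared core have been measured in an ADME assay on PC-3 cells (Homo sapiens) for cytotoxicity, read by WST assay, tested at 100 uM; a higher number here means more inhibition at the concentration tested (going by the name of the read-out), a lower number less inhibition. Compound 1 gives 0%, compound 2 gives 0% and compound 3 gives 1%. Compound 3 holds the highest of the three numbers, yet all three sit within the scatter of one another, so no order among them can be read. The steps confirm this: no change at the digits printed from compound 1 to compound 2 (within the scatter), a number 1 percentage points higher from compound 1 to compound 3 (within the scatter) and a number 1 percentage points higher from compound 2 to compound 3 (within the scatter).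

The next compound is compound 4, `Cn1cnnc1-c1cccc(NC(=O)C2CCCN(C(=O)c3cc(C(F)(F)F)cc(C(F)(F)F)c3)C2)c1`. It differs from compound 3 in one place: 4-methyl-4H-1,2,4-triazol-3-yl in place of phenoxy on an aromatic carbon. Among the measured compounds shown here, no measured step involves this entering group, but the three measured steps all change the same aromatic carbon or the group on its oxygen, and none moved the read-out beyond the scatter. By analogy, no shift beyond the scatter is expected here either.

Compound 4 is thus expected to show no change at the digits printed from compound 3 to compound 4 (within the scatter). Compound 4 is estimated at 1%, with a range from 0% to 8%.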

Compound 4, a percentage reported as inhibition, at one concentration (the size of the read-out at that concentration, not a potency): 0%
For compound 4 the middle estimate is 1 percentage points above the measured one; the range from low to high includes it.
By their numbers in this assay, from the lowest: compounds 1, 2, 4 and 3 (each within the scatter of the next).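

In this assay, 4-methyl-4H-1,2,4-triazol-3-yl in place of phenoxy gives a number 1 percentage points lower from compound 3 to compound 4 (within the scatter), in place of ethyl it gives no change at the digits printed from compound 2 to compound 4 (within the scatter), and in place of (pyridin-2-yl)oxy it gives no change at the digits printed from compound 1 to compound 4 (within the scatter). Among the compounds shown here, the aromatic carbon had so far carried only ethyl or an oxygen-linked six-membered aromatic ring, so this result extends the series to a five-membered aromatic ring with 3 hetero atoms attached directly, and all four compounds remain within the scatter of one another, with none going against this. No evidence is available that would explain this result.

The compounds shown leave open whether any group on this aromatic carbon can move the read-out beyond the scatter, for example a primary amine or a carboxylic acid, since only neutral groups have been seen here. They also leave open whether a change elsewhere on the shared core would do so, such as replacing one of the two trifluoromethyl groups with a chlorine or a methoxy group, because every compound shown carries the same bis(trifluoromethyl)benzoyl part.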